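Notes on replacing ethynyl with 1,1-difluoroethyl

The source may hold more compounds than are shown below. What is called first, only, known or untested is meant among the compounds shown, and "the series" means these compounds.

- compound 1 `Cc1cccc(N2C(=O)CSC2c2cccc(C(=O)NCCCCc3ccccc3)c2)c1`: 3140 mL.min-1.g-1
- compound 2 `O=C(NCCCCc1ccccc1)c1cccc(C2SCC(=O)N2c2cccc(-c3c[nH]nn3)c2)c1`: 742 mL.min-1.g-1
- compound 3 `C#Cc1cccc(N2C(=O)CSC2c2cccc(C(=O)NCCCCc3ccccc3)c2)c1`: 1820 mL.min-1.g-1

All three values come from an ADME assay on microsomes from liver (Rattus norvegicus) for metabolic stability, read by LC-MS, using NADPH, with a stated time of 10 min, tested at 0.1 uM; a higher number here means faster removal of the compound, a lower number slower removal. Compound 3 lies close to compound 1, since a 1.7-fold lower number from compound 1 to compound 3 (0.24 log units; within the scatter) stays within the scatter, while a 2.5-fold higher number from compound 2 to compound 3 (0.39 log units; beyond the scatter) goes beyond it.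

The next compound is compound 4 `CC(F)(F)c1cccc(N2C(=O)CSC2c2cccc(C(=O)NCCCCc3ccccc3)c2)c1`, with 1,1-difluoroethyl in place of ethynyl on an aromatic carbon, meta to a large group: 1,1-difluoroethyl in place of ethynyl on an aromatic carbon.

Within the data shown here, no measured compound carries 1,1-difluoroethyl, so the evidence is indirect. The measured steps all fall at this same place. Methyl and ethynyl are not separated by the data, and only the 1H-1,2,3-triazol-4-yl group gives a step beyond the scatter, a modest one, a 4.2-fold lower number from compound 1 to compound 2 (0.63 log units; beyond the scatter).

No step beyond the scatter is therefore expected in this assay, and neither direction is favoured. The expected step is a 1.1-fold higher number from compound 3 to compound 4 (0.04 log units; within the scatter). Compound 4 is estimated at 2000 mL.min-1.g-1, with an expected range of 1000 mL.min-1.g-1 to 3800 mL.min-1.g-1.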

Compound 4, intrinsic clearance in microsomes: 2320 mL.min-1.g-1
Compound 4: the middle estimate sits 1.2-fold (0.06 log units) below what was measured; measured number inside the range.
By their numbers in this assay, from the lowest: compound 2; then compounds 3, 4 and 1 (each within the scatter of the next).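

In this assay the steps of a 1.3-fold higher number from compound 3 to compound 4 (0.11 log units; within the scatter) and a 1.4-fold lower number from compound 1 to compound 4 (0.13 log units; within the scatter) place 1,1-difluoroethyl with methyl and ethynyl, three groups on this aromatic carbon that the data do not separate. The step of a 3.1-fold higher number from compound 2 to compound 4 (0.50 log units; beyond the scatter) extends the separation of the 1H-1,2,3-triazol-4-yl group to this third small group, so that group remains the only one shown that stands apart at this place. Nothing available explains any of these steps.

Going by these compounds, whether an amine, a carboxylic acid or another ring at this place would also stand apart from methyl, ethynyl and 1,1-difluoroethyl remains open. Also open, on these data alone, is whether these steps would hold with a shorter chain on the amide.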